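The compounds below may be only part of what the source reports. "The series", "measured", "known", "first", "only" and "open" are said of these compounds alone.

Measured so far:
compound 1 `O=C1NCCN1c1ccc(S(=O)(=O)Nc2cccc(Br)c2)cc1`, 100 nM
compound 2 `COc1ccccc1NS(=O)(=O)c1ccc(N2CCNC2=O)cc1`, 770 nM

Both numbers come from a functional assay on MCF7 cells (Homo sapiens) for antiproliferative activity, read by sulforhodamine B assay, with a stated time of 48 h; a lower number here means a stronger inhibitor, a higher number a weaker inhibitor. Within the data shown here, compound 2 stands at the higher of the two numbers; the single step in hand, a 7.7-fold higher number from compound 1 to compound 2 (0.89 log units; beyond the scatter), is beyond the scatter and shows that exchanging the aryl group on the sulfonamide nitrogen moves this assay by a modest amount.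

Compound 3 `Cc1cc(C)cc(NS(=O)(=O)c2ccc(N3CCNC3=O)cc2)c1` is not yet measured. Its change from compound 2 is 3,5-dimethylphenyl in place of 2-methoxyphenyl on a sulfonamide nitrogen. Among the measured compounds shown here, the only step that bears on it is the same kind of exchange at the same place, a 7.7-fold higher number from compound 1 to compound 2 (0.89 log units; beyond the scatter). The 3,5-dimethylphenyl has not been seen, so the direction is uncertain; a number lower than that of compound 2, partly back toward compound 1, is expected, with a wide range. In this assay compound 3 is expected to give 250 nM, within 70 nM to 900 nM. The expected step is a 3.1-fold lower number from compound 2 to compound 3 (0.49 log units; beyond the scatter).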

Compound 3, half-maximal inhibitory concentration: 100 nM
Compound 3: the middle estimate sits 2.5-fold (0.40 log units) above what was measured, within the range that was stated.
By their numbers in this assay, from the lowest: compounds 1 and 3 (each within the scatter of the next); then compound 2.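

In this assay, 3,5-dimethylphenyl in place of 2-methoxyphenyl on a sulfonamide nitrogen gives a 7.7-fold lower number from compound 2 to compound 3 (0.89 log units; beyond the scatter) and shows that the higher number of compound 2 does not extend to every replacement for 3-bromophenyl. Exchanging 3-bromophenyl for 3,5-dimethylphenyl at the same place gives no change at the digits printed from compound 1 to compound 3 (within the scatter) so bromine is not required at this position to reach the number of compound 1, and of the three aryl groups only 2-methoxyphenyl stands apart. No measurement at hand explains the difference among these aryl groups.

The compounds shown do not separate the effect of the methoxy group itself from that of its placement on the ring. They also leave open how this position responds to an aryl ring carrying an amine or a carboxylic acid, or to a longer alkyl chain in place of the aryl ring.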